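Fluoro to bromo on the 1-fluoroethenyl group

The source may hold more compounds than are shown below. What is called first, only, known or untested is meant among the compounds shown, and "the series" means these compounds.

In a functional assay on NCI-H1975 cells (Homo sapiens) for antiproliferative activity, read by sulforhodamine B assay, with a stated time of 72 h (a lower number here means a stronger inhibitor, a higher number a weaker inhibitor), compound 1 (`C=C(C(=O)Nc1cc(Nc2nccc(-c3cn(C)c4ccccc34)n2)c(OC)cc1N(C)CCN(C)C)C(F)(F)F`) gives 546 nM and compound 2 (`C=C(F)C(=O)Nc1cc(Nc2nccc(-c3cn(C)c4ccccc34)n2)c(OC)cc1N(C)CCN(C)C`) gives 208 nM, the lower of the two numbers. Compound 3 (`C=C(Br)C(=O)Nc1cc(Nc2nccc(-c3cn(C)c4ccccc34)n2)c(OC)cc1N(C)CCN(C)C`) differs from compound 2 by bromo in place of fluoro on a double-bonded chain carbon bound to a carbonyl carbon, with bromo in place of fluoro on a double-bonded chain carbon bound to a carbonyl carbon. Going by the values given here, the only measured step at this place is modest: a 2.6-fold lower number from compound 1 to compound 2 (0.42 log units; beyond the scatter). It involves no bromo group, so it gives no firm direction. In this assay, no step beyond the scatter is expected. The estimated step is a 1.2-fold lower number from compound 2 to compound 3 (0.09 log units; within the scatter). The estimate for compound 3 is 170 nM, with an expected range of 60 nM to 500 nM.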

Compound 3, half-maximal inhibitory concentration: 147 nM
Beside the measured number, compound 3's estimate is 1.2-fold (0.06 log units) above it, within the range that was stated.
By their numbers in this assay, from the lowest: compounds 3 and 2 (each within the scatter of the next); then compound 1.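

In this assay, bromo in place of fluoro on the double-bonded chain carbon bound to a carbonyl carbon gives a step within the scatter (a 1.4-fold lower number from compound 2 to compound 3 (0.15 log units; within the scatter)), so this assay does not separate the two halogens. Bromo in place of trifluoromethyl gives a step beyond the scatter (a 3.7-fold lower number from compound 1 to compound 3 (0.57 log units; beyond the scatter)), leaving trifluoromethyl as the only group here set apart from both others. No evidence on hand accounts for either step.

Still open, on these data alone, is whether chloro or methyl at this place would read with fluoro and bromo or with trifluoromethyl. Also open, as far as these compounds go, is how an amine on a longer chain there would read.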